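Removing a Benzyl Group from an Untested Analogue of Compound 2

The source may report more compounds than this note shows. Statements on the series, on what has been measured and on what is new or still open speak of the compounds shown alone.

Compound 1 `C[Se]c1nc(N)c2ccccc2n1`: > 100000 nM
Compound 2 `CCCCC[Se]c1nc(NCc2ccccc2)c2ccccc2n1`: > 100000 nM

Of the compounds shown here, two have been tested in a functional assay on HT-29 cells (Homo sapiens) for cytotoxicity, read by MTT assay, with a stated time of 72 h; a lower number here means that less compound is tolerated, a higher number that more compound is tolerated. Compound 1 gives > 100000 nM in this assay, which is a limit of the assay and not a number. Compound 2 likewise gives > 100000 nM in this assay, again a limit rather than a measured value. Going by the values given here, compound 2 therefore stands at the limit, and so does the only other value, as summed up by the limit of > 100000 nM in this assay, at which 2 of the 2 values shown sit.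

The next compound, compound 3 `CCCCC[Se]c1nc(N)c2ccccc2n1`, differs from compound 2 by hydrogen in place of benzyl on a nitrogen on an aromatic ring. Among the compounds with values here, no step between measured compounds is available, so nothing shows how large such a change can be. With both measured values sitting at the limit, the step from compound 2 to compound 3 is expected to be a number no higher from compound 2 to compound 3 (the limit leaves the size open), that is, none beyond the scatter. Compound 3 is estimated at 100000 nM, between 30000 nM and 300000 nM, and the assay will most likely again report only a limit.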

Compound 3, concentration lethal to 50% of the cells: > 100000 nM
Compound 3: no number, only a limit (the forecaster's own chance of this, stated with the estimate: 85%); the middle value sits exactly at the limit.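

No step can be read from compound 2 to compound 3 or from compound 1 to compound 3, because all of these results are limits and not numbers: the limit of > 100000 nM in this assay, at which 3 of the 3 values shown sit.

The compounds shown leave open whether exchanging benzyl for hydrogen or adding butyl to the chain on selenium changes the result in this assay.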